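The source may report more compounds than this note shows. Statements on the series, on what has been measured and on what is new or still open speak of the compounds shown alone.

Among the measured compounds shown here, compound 3 `CN(C)/C(=N/CCCn1nc(-c2ccccc2)ccc1=O)NC#N` gives 53 mg/kg in a functional assay on the whole organism (stomach) with Rattus norvegicus as the target (a lower number here means that less compound is needed, a higher number that more compound is needed for the effect), and it holds the only plain number among the three measured compounds. Compound 1 `N#CNC(=N)NCCCn1nc(-c2ccccc2)ccc1=O` reaches only a limit of the assay, > 100 mg/kg. Compound 2 `C/N=C(\S)NCCCn1nc(-c2ccccc2)ccc1=O` likewise stops at a limit, > 100 mg/kg. Compound 4 `CC/N=C(\S)NCCCCCn1nc(-c2ccccc2)ccc1=O` has not been measured; it differs from compound 3 by a group of 8 heavy atoms (5 carbon, 2 nitrogen, 1 sulfur; no ring) in place of a group of 8 heavy atoms (4 carbon, 4 nitrogen; no ring), on a saturated chain carbon, three bonds along the chain from an aromatic nitrogen. For the measured compounds named here, the steps that bear on this are an at least 1.8-fold lower number from compound 1 to compound 3 (0.27 log units; that floor lies within the scatter) and an at least 1.8-fold lower number from compound 2 to compound 3 (0.27 log units; that floor lies within the scatter), both running toward compound 3 from compounds that sit at the limit of > 100 mg/kg in this assay, at which 2 of the 3 values shown sit. Moving away from the group of compound 3 is therefore expected to raise the number in this assay, so compound 4 is estimated at 120 mg/kg, within 40 mg/kg to 300 mg/kg, an expected step of a 2.3-fold higher number from compound 3 to compound 4 (0.35 log units; beyond the scatter).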

Compound 4, dose for half-maximal effect: 51.8 mg/kg
For compound 4 the middle estimate is 2.3-fold (0.36 log units) above the measured one, and the stated range covers the measured number.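

Replacing the group of compound 3 with the sulfur-bearing group of compound 4 at this saturated chain carbon gives a 1.0-fold lower number from compound 3 to compound 4 (0.01 log units; within the scatter), so these two different groups cannot be told apart in this assay. The other new steps are an at least 1.9-fold lower number from compound 2 to compound 4 (0.28 log units; that floor lies within the scatter) and an at least 1.9-fold lower number from compound 1 to compound 4 (0.28 log units; that floor lies within the scatter). Both are only floors, and their true size cannot be read because their starting compounds stop at a limit: the limit of > 100 mg/kg in this assay, at which 2 of the 4 values shown sit.

The compounds shown leave open how an amine or a carboxylic acid would compare in this place. They also do not separate the effect of a longer chain from that of the other changes in the group.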